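The compounds below may be only part of what the source reports. "The series", "measured", "known", "first", "only" and "open" are said of these compounds alone.

The measured compounds:

Compound 1, `CC(=O)c1ccc(/N=C2\C=C(OCc3cn(S(=O)(=O)c4ccc(C)cc4)nn3)C(=O)c3ccccc32)cc1`; in a functional assay on K562 cells (Homo sapiens) for cytotoxicity, read by MTT assay, with a stated time of 72 h (a lower number here means a stronger inhibitor, a higher number a weaker inhibitor), compound 1 gives 5520 nM.
Compound 2, `Cc1ccc(S(=O)(=O)n2cc(COC3=C/C(=N\c4ccc(I)cc4)c4ccccc4C3=O)nn2)cc1`; in this assay compound 2 gives 10800 nM.

Among the compounds with values here, compound 1 has the lowest of these two numbers, and compound 2 is its only neighbour, with a 2.0-fold higher number from compound 1 to compound 2 (0.29 log units; within the scatter), a gap that is within the scatter. The new compound 3, `Cc1ccc(S(=O)(=O)n2cc(COC3=C/C(=N\c4ccc(Cl)cc4)c4ccccc4C3=O)nn2)cc1`, differs from compound 1 in one place: chloro in place of acetyl on an aromatic carbon. Within the data shown here, only one measured step bears on this change: the one from compound 1 to compound 2, which also puts a halogen in place of the acetyl, and that step was a 2.0-fold higher number from compound 1 to compound 2 (0.29 log units; within the scatter). A halogen swap of this kind is therefore expected to move the number little, if at all, beyond the scatter in this assay. Compound 3 is estimated at 7500 nM, with a range from 3200 nM to 17000 nM. That estimate means an expected step of a 1.4-fold higher number from compound 1 to compound 3 (0.13 log units; within the scatter), within the scatter.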

Compound 3, half-maximal inhibitory concentration: 9800 nM
For compound 3 the middle estimate is 1.3-fold (0.12 log units) below the measured one; the range from low to high includes it.
By their numbers in this assay, from the lowest: compounds 1, 3 and 2 (each within the scatter of the next).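

Going from the 4-acetylphenyl to the 4-chlorophenyl group in this assay gives a 1.8-fold higher number from compound 1 to compound 3 (0.25 log units; within the scatter) with no other change, and exchanging iodo for chloro gives a 1.1-fold lower number from compound 2 to compound 3 (0.04 log units; within the scatter) on the same aromatic carbon. Within the data shown here, the single earlier step could not show whether iodo was a special case, but there are now three different groups at this position, two halogens and an acetyl, and every step among them lies within the scatter, so this assay does not tell them apart. Nothing measured here offers a reason for this flat reading.

On these data alone, it remains open whether an amine, a carboxylic acid or a longer chain on this aromatic carbon would separate from these three. All three compounds also share the rest of the structure, so what a change elsewhere in the core would do is equally unknown.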